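The compounds below may be only part of what the source reports. "The series", "measured", "known", "first", "only" and "open" are said of these compounds alone.

Measured in a functional assay on Jurkat cells (Homo sapiens) for antiproliferative activity, read by MTT assay; on this read-out lower numbers stand for stronger inhibition and higher numbers for weaker inhibition:
- compound 1 `COc1ccccc1/C=C1\CCc2cc(OC)c(OC)cc2C1=O`: > 50000 nM (a limit of the assay, not a number)
- compound 2 `COc1cccc(/C=C2\CCc3cc(OC)c(OC)cc3C2=O)c1`: 5000 nM
- compound 3 `COc1cc2c(cc1OC)C(=O)/C(=C/c1ccc(O)cc1)CC2`: 19000 nM

Among the two actual numbers, compound 2 has the lower, at 5000 nM. The nearest comparison is a 3.8-fold higher number from compound 2 to compound 3 (0.58 log units; beyond the scatter), which is beyond the scatter. Compound 4 `COc1cc2c(cc1OC)C(=O)/C(=C/c1cccc(OC)c1OC)CC2` differs from compound 2 by methoxy in place of hydrogen on an aromatic carbon. The new group sits ortho to a large group and ortho to a methoxy group.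

Among the compounds with values here, no measured pair shows this addition directly. The closest evidence is an at least 10-fold lower number from compound 1 to compound 2 (1.00 log units; beyond the scatter), and it gives only a minimum size. Read in reverse, it links the 2-methoxyphenyl of compound 1 with the weaker result. Compound 4 keeps the 3-methoxyphenyl of compound 2 but also gains a methoxy at the place it occupies in compound 1. Compound 4 is therefore expected to lose part of the activity of compound 2, though probably not all of it, since the 3-methoxyphenyl pattern remains. The expected change is a 3.0-fold higher number from compound 2 to compound 4 (0.48 log units; beyond the scatter), a modest move toward weaker inhibition. For compound 4, the estimated value is 15000 nM, with an expected range of 4000 nM to 50000 nM.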

Compound 4, half-maximal inhibitory concentration: > 50000 nM
Compound 4 ended at the assay's limit; the forecaster's own chance of this, stated with the estimate: 20%; middle value at least 3.3-fold (0.52 log units) away from the limit.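

In this assay, within the data shown here, methoxy in place of hydrogen on the aromatic carbon ortho to a large group and ortho to a methoxy group gives an at least 10-fold higher number from compound 2 to compound 4 (1.00 log units; beyond the scatter), the first direct reading of this change, as the earlier steps only exchanged one substituted phenyl for another. The 3-methoxyphenyl pattern of compound 2 therefore does not hold the activity once methoxy fills this place, and among the compounds shown, the two with methoxy there, compound 1 and compound 4, both lack a numerical value, while compound 2 and compound 3, with hydrogen there, both have one. Compound 1 and compound 4 each stand at a limit of the assay, not a number, and the step between them cannot be read.

As far as these compounds go, whether fluorine or an amine at this place would keep any of the activity of compound 2 remains open. How far the loss extends also remains open, as the readings in this series stop at the limit: the limit of > 50000 nM in this assay, at which 2 of the 4 values shown sit.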